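The source may report more compounds than this note shows. Statements on the series, on what has been measured and on what is new or still open speak of the compounds shown alone.

For the measured compounds named here, in an assay for inhibition of inositol hexakisphosphate kinase 2 (Homo sapiens), read by colorimetric assay, coupled enzyme assay and malachite green, with a stated time of 120 min, in the presence of a further agent that is not named here (a higher number here means a weaker inhibitor, a lower number a stronger inhibitor), compound 1 `O=C(O)c1ccc2noc(-c3ccc(N4CCCCC4)cc3)c2c1` gives 240 nM, the lowest of the three numbers measured so far. Compound 2 `O=C(O)c1ccc2noc(-c3ccc(Oc4ccccn4)cc3)c2c1` gives 1190 nM and compound 3 `O=C(O)c1ccc2noc(-c3ccc(N4CCCC4=O)cc3)c2c1` gives 480 nM. The unmeasured compound 4 `O=C(O)c1ccc2noc(-c3ccc(NC(=O)c4ccncn4)cc3)c2c1` differs from compound 1 by ((pyrimidin-4-yl)carbonyl)amino in place of piperidin-1-yl on an aromatic carbon. Two measured steps at the same aromatic carbon bear on this change: a 5.0-fold higher number from compound 1 to compound 2 (0.70 log units; beyond the scatter), and a 2.0-fold higher number from compound 1 to compound 3 (0.30 log units; within the scatter). The incoming group carries a carbonyl, as in compound 3, and a second aromatic ring attached through a linker, as in compound 2. For compound 4 a modest rise toward weaker inhibition is therefore expected, a 2.9-fold higher number from compound 1 to compound 4 (0.46 log units; beyond the scatter). Compound 4 is estimated at 700 nM, with a range from 250 nM to 2000 nM.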

Compound 4, half-maximal inhibitory concentration: 720 nM
Compound 4: the middle estimate sits 1.0-fold (0.01 log units) below what was measured; the measured number falls inside the stated range.
By their numbers in this assay, from the lowest: compounds 1, 3, 4 and 2 (each within the scatter of the next, the first and the last beyond it).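

Swapping piperidin-1-yl for ((pyrimidin-4-yl)carbonyl)amino at this aromatic carbon gives a 3.0-fold higher number from compound 1 to compound 4 (0.48 log units; beyond the scatter), so a group holding both a carbonyl and a second aromatic ring still leaves measurable inhibition. Compound 4 cannot be told apart from the other two compounds: a 1.5-fold higher number from compound 3 to compound 4 (0.18 log units; within the scatter) and a 1.7-fold lower number from compound 2 to compound 4 (0.22 log units; within the scatter). No measurement here explains these differences. Still open, going by these compounds, is how a simple acetamide, lacking the pyrimidine ring, or a primary amine at this aromatic carbon would compare. A methyl group on the amide nitrogen, replacing the amide hydrogen, is also untested among the compounds shown.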